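The compounds below may be only part of what the source reports. "The series", "measured", "known", "first", "only" and "open" are said of these compounds alone.

In a functional assay on A549 cells (Homo sapiens) for inhibition, read by MTT assay, with a stated time of 48 h (on this read-out lower numbers stand for stronger inhibition and higher numbers for weaker inhibition), compound 1 (`CCc1ccc(-c2nc3ccccn3c2Sc2ccccc2)cc1`) gives 56200 nM and shares the high end of the numbers with compound 2 (`c1ccc(Sc2c(-c3ccccc3)nc3ccc(-c4ccccc4)cn23)cc1`), which gives 54200 nM within the scatter of compound 1. Compound 3 (`CS(=O)(=O)c1ccc(-c2nc3ccccn3c2Sc2cccc3ccccc23)cc1`) gives 19600 nM as a lower number, beyond the scatter from compound 1. Compound 4 (`Clc1ccc(-c2nc3ccccn3c2Sc2ccccc2)cc1`) differs from compound 1 in one place (chloro in place of ethyl on an aromatic carbon): chloro in place of ethyl on an aromatic carbon, so 4-ethylphenyl becomes 4-chlorophenyl. Going by the values given here, no measured pair shows this change, so in this assay no step beyond the scatter is expected in either direction. The estimated step (a 1.2-fold lower number from compound 1 to compound 4 (0.10 log units; within the scatter)) is expected to stay small. For compound 4 the expected value is 45000 nM with an estimated range from 18000 nM to 100000 nM in this measurement.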

Compound 4, half-maximal inhibitory concentration: 22000 nM
Compound 4: middle estimate off by 2.0-fold (0.31 log units), on the high side; low and high end bracket the measured number.
By their numbers in this assay, from the lowest: compounds 3 and 4 (each within the scatter of the next); then compounds 2 and 1 (each within the scatter of the next).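

In this assay, going by these compounds alone, exchanging ethyl for chloro gives a 2.6-fold lower number from compound 1 to compound 4 (0.41 log units; beyond the scatter), the first step here that can be read between two compounds differing in one place. It shows that the group on this aromatic carbon, para to a large group, can shift the number beyond the usual scatter, though the step is modest. Nothing measured here explains the step. Going by these compounds, whether an amine, a carboxylic acid or a longer chain at this position would shift the number further remains open. So does whether the same exchange gives a similar step in other members of the series.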